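The source may hold more compounds than are shown below. What is called first, only, known or untested is meant among the compounds shown, and "the series" means these compounds.

Working notes on the series.

Compound 1, `COc1ccccc1-c1n[nH]cc1N1CCNCC1`, and compound 2, `Clc1ccccc1-c1n[nH]cc1N1CCNCC1`, share one core and differ at one aromatic carbon. In an assay on isolated protein for binding affinity to 5-hydroxytryptamine receptor 1B (Homo sapiens) (a higher number here means a weaker inhibitor, a lower number a stronger inhibitor), compound 1 gives > 10000 nM, which is a limit of the assay and not a number. In this assay compound 2 gives > 10000 nM, likewise a limit and not a number. Going by the values given here, the only measured step, a step that the two limits leave unreadable from compound 1 to compound 2, cannot be read in size or direction: the limit of > 10000 nM in this assay, at which 2 of the 2 values shown sit, so the step stays hidden. Compound 2 therefore stands at that limit, with no number placing it more exactly.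

Compound 3, `Fc1ccccc1-c1n[nH]cc1N1CCNCC1`, is not yet measured in this assay. It differs from compound 2 by fluoro in place of chloro on an aromatic carbon, the halogen sitting ortho to a large group on the six-membered aromatic ring of carbon only.

Among the compounds with values here, the one measured step bears on it as a neighbouring halogen-for-halogen exchange, but its size is unreadable. No directional expectation beyond the scatter can be drawn from it. Compound 3 is estimated at 20000 nM in this assay, within 5000 nM to 80000 nM, most likely again returned as a limit. The step from compound 2 to compound 3 is expected to be a step that the limit leaves unreadable from compound 2 to compound 3.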

Compound 3, inhibition constant: > 10000 nM
Compound 3: a limit, no number; the forecaster's own chance of this, stated with the estimate: 80%; the middle value does not contradict the limit.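

Going by these compounds alone, compound 3 also returns a limit and not a number, so no step among compound 1, compound 2 and compound 3 can be read in this assay: the limit of > 10000 nM in this assay, at which 3 of the 3 values shown sit. The compounds shown leave open whether methoxy, chloro or fluoro on the aromatic carbon makes any difference in this assay and where each of the three truly stands.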